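Closing a Chain into a Ring on the Shared Core

This account rests on a few compounds, and the source may have more. Where it says the series, first, only, none or still open, it means among the compounds named here.

Of the compounds shown here, two on a shared core have been measured for how quickly liver microsomes clear them. In an ADME assay on microsomes from liver (Rattus norvegicus) for metabolic stability (on this read-out lower numbers stand for slow clearance and higher numbers for fast clearance), compound 1 `CCCC(C#N)(CC)Nc1nc(NC)nc(-n2cncn2)n1` gives 29 mL/min/kg. Compound 2 `CCC(C)(C#N)Nc1nc(NC)nc(-n2cncn2)n1` gives 32 mL/min/kg in this assay. The only step between them, a 1.1-fold higher number from compound 1 to compound 2 (0.04 log units; within the scatter), is within the scatter, so on the numbers shown compound 2 sits together with compound 1 rather than apart from it.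

Compound 3 `CNc1nc(NC2(C#N)CCCC2)nc(-n2cncn2)n1` has not yet been measured. It differs from compound 2 in one place: 1-cyanocyclopentyl in place of 1-cyano-1-methylpropyl on a nitrogen on an aromatic ring. Among the measured compounds shown here, the one measured step that touches this part of the molecule, a 1.1-fold higher number from compound 1 to compound 2 (0.04 log units; within the scatter), altered the chain on that same saturated carbon and moved the number by less than the scatter. For the measured compounds named here, no measured step joins such a chain into a ring, so the expectation rests on that single flat step alone. The step of no change at the digits printed from compound 2 to compound 3 (within the scatter) is therefore expected to stay within the scatter. Compound 3 is estimated to give 32 mL/min/kg in this assay, within a range from 16 mL/min/kg to 64 mL/min/kg.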

Compound 3, clearance: 43 mL/min/kg
Estimate against measurement, compound 3: 1.3-fold (0.13 log units) below, within the range that was stated.
By their numbers in this assay, from the lowest: compounds 1, 2 and 3 (each within the scatter of the next).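

Closing the open chain into a ring, with 1-cyanocyclopentyl in place of 1-cyano-1-methylpropyl on a nitrogen on an aromatic ring, gives a 1.3-fold higher number from compound 2 to compound 3 (0.13 log units; within the scatter) in this assay and so stays inside the usual spread of repeat measurements. Compounds 1 and 2 carry only open chains at this place, so compound 3 adds a new kind of change: one five-membered non-aromatic ring of carbon only, with the nitrile kept, and on these three compounds neither altering the chain nor closing it into this ring gives a step beyond the scatter. The compounds shown offer no measurement that would explain the number for this ring, so the result stands as an observation without a cause.

Still open, going by these compounds, is whether a larger or smaller ring would also stay within the scatter at this place, for example a six-membered ring of carbon only, a cyclopropyl ring, or a ring that holds an oxygen atom. On these data alone, it is equally open how the clearance would respond if the nitrile on this carbon gave way to a carboxylic acid or an amide.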